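Moving the thiophene attachment on compound 2

The source may report more compounds than this note shows. Statements on the series, on what has been measured and on what is new or still open speak of the compounds shown alone.

Among the compounds with values here, in a functional assay on ileum (Cavia porcellus) for inhibition (a lower number here means a stronger inhibitor, a higher number a weaker inhibitor), compound 2 `COC(=O)C1=C(C)NC(C)=C(C(=O)OC)C1c1c(-c2ccsc2)nc2sc(C)cn12` gives 3520 nM, the second highest of the three numbers so far. Compound 1 `COC(=O)C1=C(C)NC(C)=C(C(=O)OC)C1c1c(-c2cccnc2)nc2sc(C)cn12` stands higher at 16000 nM, and compound 3 `COC(=O)C1=C(C)NC(C)=C(C(=O)OC)C1c1c(-c2ccsc2)nc2sccn12` stands far lower at 2.3 nM. The next compound to be tested, compound 4 `COC(=O)C1=C(C)NC(C)=C(C(=O)OC)C1c1c(-c2cccs2)nc2sc(C)cn12`, has the same atoms as compound 2, joined differently: thiophen-2-yl in place of thiophen-3-yl on an aromatic carbon. The ring is now attached through thiophen-2-yl in place of thiophen-3-yl, on the same aromatic carbon that carries the changing group in the modest step of a 4.5-fold lower number from compound 1 to compound 2 (0.66 log units; beyond the scatter). That step is the closest guide, since it exchanged pyridin-3-yl for thiophen-3-yl at this carbon. The large step of a 1500-fold lower number from compound 2 to compound 3 (3.18 log units; beyond the scatter) replaced methyl with hydrogen at a different aromatic carbon. Compound 4 keeps that methyl, so this step bears on the change only as a warning that numbers in this set can move far. Within the data shown here, no measured pair compares the two thiophene attachments, and the data give no direction. A small change is expected, no larger than the modest step above, and the estimated step is a 1.2-fold lower number from compound 2 to compound 4 (0.07 log units; within the scatter). For compound 4 the expected value is 3000 nM, with an estimated range of 900 nM to 11000 nM.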

Compound 4, half-maximal inhibitory concentration: 1370 nM
For compound 4 the middle estimate is 2.2-fold (0.34 log units) above the measured one; measured number inside the range.
By their numbers in this assay, from the lowest: compound 3; then compound 4; then compound 2; then compound 1.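

Joining the thiophene through a different ring carbon, with the atoms and the counted features unchanged, is enough to shift the result at this aromatic carbon next to the ring nitrogen: in this assay there is a 2.6-fold lower number from compound 2 to compound 4 (0.41 log units; beyond the scatter). Within the data shown here, this is the first direct comparison of the two attachments, and with the methyl kept, it places thiophen-2-yl ahead of thiophen-3-yl, while the comparison with pyridin-3-yl gives a 12-fold lower number from compound 1 to compound 4 (1.07 log units; beyond the scatter), so among the three groups tried here, the order runs thiophen-2-yl, thiophen-3-yl, pyridin-3-yl. Even so, the attachment change remains much smaller than a 1500-fold lower number from compound 2 to compound 3 (3.18 log units; beyond the scatter), and no measurement offered here explains the difference between the two thiophene attachments.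

The compounds shown leave open whether thiophen-2-yl would still lead thiophen-3-yl with hydrogen in place of the methyl, the setting in which compound 3 gives 2.3 nM. Also open, from the compounds shown here alone, is where a phenyl or a furan-2-yl ring would fall in this order on the same aromatic carbon.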